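The source may report more compounds than this note shows. Statements on the series, on what has been measured and on what is new or still open speak of the compounds shown alone.

Measured so far:
compound 1 `Cc1ccc(-c2c(C)nn(-c3nc(-c4ccc(Cl)c(Cl)c4)c(SC(C)C)s3)c2C(=O)O)cc1` — 3800 nM
compound 2 `Cc1nn(-c2nc(-c3ccc(Cl)c(Cl)c3)c(SC(C)C)s2)c(C(=O)O)c1-c1cncc(C#N)c1` — 20000 nM
compound 3 `Cc1nn(-c2nc(-c3ccc(Cl)c(Cl)c3)c(SC(C)C)s2)c(C(=O)O)c1-c1ccccc1[N+](=O)[O-]` — 4700 nM

In a functional assay on BJAB cells (Homo sapiens) for antiproliferative activity, with a stated time of 4 days (a higher number here means that more compound is needed for the effect, a lower number that less compound is needed), compound 3 sits within the scatter of compound 1 and gives a lower number than compound 2 (a 4.3-fold lower number from compound 2 to compound 3 (0.63 log units; beyond the scatter)). Compound 4 `Cc1nn(-c2nc(-c3ccc(Cl)c(Cl)c3)c(SC(C)C)s2)c(C(=O)O)c1-c1ccc(C(F)(F)F)cc1` is next: 4-(trifluoromethyl)phenyl in place of 2-nitrophenyl on an aromatic carbon. Two measured steps change the aryl group at this same position. One is a 1.2-fold higher number from compound 1 to compound 3 (0.09 log units; within the scatter), within the scatter; the other is a 5.3-fold higher number from compound 1 to compound 2 (0.72 log units; beyond the scatter), beyond it. Compound 1 carries a para-substituted phenyl like the one entering, so the nearer guide is the small step, and compound 4 is expected to stay close to compound 3, with a 1.3-fold lower number from compound 3 to compound 4 (0.13 log units; within the scatter) likely within the scatter. For compound 4 the estimate is 3500 nM, with a range of 1500 nM to 9000 nM.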

Compound 4, half-maximal effective concentration: 3500 nM
Compound 4: the middle estimate sits on the measured number at the digits printed; low and high end bracket the measured number.
By their numbers in this assay, from the lowest: compounds 4, 1 and 3 (each within the scatter of the next); then compound 2.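

In this assay, trifluoromethyl in place of methyl gives no separation beyond the scatter (a 1.1-fold lower number from compound 1 to compound 4 (0.04 log units; within the scatter)), and the same holds for 4-(trifluoromethyl)phenyl in place of 2-nitrophenyl (a 1.3-fold lower number from compound 3 to compound 4 (0.13 log units; within the scatter)). The three substituted phenyl groups at this position now lie within the scatter of one another, while 5-cyanopyridin-3-yl stands apart (a 5.7-fold lower number from compound 2 to compound 4 (0.76 log units; beyond the scatter)). No measurement on hand bears on the reason for this result.

Compound 2 differs from the others in both its ring nitrogen and its nitrile, and the compounds shown do not separate the two. Where a plain pyridin-3-yl, a phenyl carrying a nitrile or a phenyl carrying an amine would fall remains open.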